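Moving the Pyrazole Link on a Shared Core

A few compounds are considered here, and "the series" means these few. Any claim that something is new, unique, unknown or untested is made for them only; others in the source may bear on it.

Of the compounds shown here, three built on one shared core have been measured in a physicochemical assay for lipophilicity, using the shake flask method, in phosphate buffer, measured as octanol-water partition, with a stated time of 30 min, at pH 7.4; on this read-out higher numbers stand for higher lipophilicity and lower numbers for lower lipophilicity. Compound 1 (`Cc1ncc(-c2cnc(NCc3c(F)ccc4c3CCO4)c3cn[nH]c(=O)c23)n1C`) gives 1.9, and compound 2 (`Cc1nc(CN(C)C)ccc1-c1cnc(NCc2c(F)ccc3c2CCO3)c2cn[nH]c(=O)c12`) gives 2. Compound 3 (`Cc1cc(-c2cnc(NCc3c(F)ccc4c3CCO4)c3cn[nH]c(=O)c23)n(C)n1`) gives 3, the highest of the three.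

Compound 4 (`Cc1nn(C)cc1-c1cnc(NCc2c(F)ccc3c2CCO3)c2cn[nH]c(=O)c12`) has not yet been measured. It has the same atoms as compound 3, joined differently: 1,3-dimethyl-1H-pyrazol-4-yl in place of 1,3-dimethyl-1H-pyrazol-5-yl on an aromatic carbon. A 1,3-dimethyl-1H-pyrazol-4-yl group takes the place of the 1,3-dimethyl-1H-pyrazol-5-yl group on an aromatic carbon, so the group keeps its name except for the final number.

Among the measured compounds shown here, no measured pair shows this exact swap, so the evidence is indirect. Exchanging one group for another on the core gave a number 1.10 log units higher from compound 1 to compound 3 (beyond the scatter) and a number 1.00 log units higher from compound 2 to compound 3 (beyond the scatter), while the remaining exchange gave a number 0.10 log units higher from compound 1 to compound 2 (within the scatter). Those exchanges replaced one whole group with a different one, whereas this change keeps the same atoms, so a smaller step than the two large ones seems likely. Compound 3, at 3, stands above both others, so a downward move seems likelier than an upward one, although nothing measured settles this.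

In this assay the expected change is a number 0.50 log units lower from compound 3 to compound 4 (beyond the scatter). The estimate for compound 4 is 2.5, with an expected range from 2 to 3.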

Compound 4, distribution coefficient: 2.8
Compound 4: the middle estimate sits 0.30 log units below what was measured, and the stated range covers the measured number.
By their numbers in this assay, from the lowest: compounds 1 and 2 (each within the scatter of the next); then compounds 4 and 3 (each within the scatter of the next).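

In this assay, joining the same pyrazole through a different ring carbon, with 1,3-dimethyl-1H-pyrazol-4-yl in place of 1,3-dimethyl-1H-pyrazol-5-yl on the aromatic carbon of the shared core, gives a step that cannot be told from repeat-measurement noise (a number 0.20 log units lower from compound 3 to compound 4 (within the scatter)). The gap seen earlier between compound 3 and the other two compounds also appears with the new attachment, since 1,3-dimethyl-1H-pyrazol-4-yl in place of 6-((dimethylamino)methyl)-2-methylpyridin-3-yl gives a number 0.80 log units higher from compound 2 to compound 4 (beyond the scatter) and 1,3-dimethyl-1H-pyrazol-4-yl in place of 1,2-dimethyl-1H-imidazol-5-yl gives a number 0.90 log units higher from compound 1 to compound 4 (beyond the scatter) on the same read-out. Nothing available here explains either the closeness of the two pyrazole compounds or their gap from the other two.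

Whether the second methyl on the pyrazole matters stays open, as the compounds shown do not include a 1-methyl-1H-pyrazol-4-yl group. As far as these compounds go, it is also open whether a plain phenyl ring, a morpholine or a carboxylic acid on this aromatic carbon would read nearer to the two pyrazole compounds or nearer to compound 1 and compound 2.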